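The source may hold more compounds than are shown below. What is called first, only, known or untested is meant among the compounds shown, and "the series" means these compounds.

Measured compounds:
compound 1, `CCCC[C@@H](CCn1cncn1)c1ccccc1`: 40.8 ug/mL
compound 2, `CCCC[C@@H](CCn1cncn1)c1ccc(Cl)cc1`: 17 ug/mL
compound 3, `c1ccc(C[C@H](CCn2cncn2)c2ccccc2)cc1`: 60.9 ug/mL

In an ADME assay on HEp-2 cells (Homo sapiens) for cytotoxicity, read by MTT assay, with a stated time of 3 days (a lower number here means that less compound is tolerated, a higher number that more compound is tolerated), compound 1 gives 40.8 ug/mL and compound 2 gives 17 ug/mL. The step of a 2.4-fold lower number from compound 1 to compound 2 (0.38 log units; beyond the scatter) comes with the change (chloro in place of hydrogen on an aromatic carbon). Compound 3, with `c1ccc(C[C@H](CCn2cncn2)c2ccccc2)cc1`, gives 60.9 ug/mL in this assay; the difference between its core and the core of compound 1 is not broken down here. Its value lies within the scatter of compound 1, while compound 2 shows a lower number than compound 3.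

Compound 4, `Clc1ccc([C@@H](CCn2cncn2)Cc2ccccc2)cc1`, has not yet been measured. It differs from compound 3 by chloro in place of hydrogen on an aromatic carbon, the same change as from compound 1 to compound 2. Among the compounds with values here, on that single earlier step, a 2.4-fold lower number from compound 1 to compound 2 (0.38 log units; beyond the scatter), the step of a 2.3-fold lower number from compound 3 to compound 4 (0.35 log units; beyond the scatter) is expected in this assay, with wide uncertainty because only one example carries it. Compound 4 is therefore estimated at 27 ug/mL, between 13 ug/mL and 55 ug/mL.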

Compound 4, half-maximal cytotoxic concentration: 25.9 ug/mL
Compound 4: middle estimate off by 1.0-fold (0.02 log units), on the high side; low and high end bracket the measured number.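

In this assay, chloro in place of hydrogen on an aromatic carbon again gives a lower number (a 2.4-fold lower number from compound 3 to compound 4 (0.37 log units; beyond the scatter)), and the step matches the earlier one: the same change on two cores in this assay, a 2.4-fold lower number (0.38 log units; beyond the scatter) from compound 1 to compound 2 and a 2.4-fold lower number (0.37 log units; beyond the scatter) from compound 3 to compound 4, 1.0-fold (0.01 log units) apart, within the scatter of two such steps.
The change therefore carries over from the core of compound 1 to the core of compound 3 with its size intact. Within the data shown here, this rests on only two cores and one pair of steps, so it does not show that the step would hold on any other core, nor does it explain the lower number.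

The compounds shown leave open whether fluoro, bromo or methoxy in the same place would give a similar step. They also leave open how an amine or a carboxylic acid on the ring would behave.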